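A Piperidinyl Group Replaces Fluoro on a Shared Core

The source may hold more compounds than are shown below. What is called first, only, known or untested is meant among the compounds shown, and "the series" means these compounds.

Compound 3 `Cc1cnc(Nc2ccc(F)cc2)nc1Nc1nc2ccccc2s1` carries a fluoro group on its outer benzene ring. In a functional assay on PC-3 cells (Homo sapiens) for antiproliferative activity, read by MTT assay, with a stated time of 48 h (on this read-out lower numbers stand for stronger inhibition and higher numbers for weaker inhibition), compound 3 gives only a limit of the assay, > 50000 nM. Its two relatives fare no differently. Compound 1 `Cc1cnc(Nc2ccc(C(C)C)cc2)nc1Nc1nc2ccccc2s1`, which bears an isopropyl group in that place, gives in this assay the limit > 50000 nM. Compound 2 `Cc1cnc(Nc2ccc(S(N)(=O)=O)cc2)nc1Nc1nc2ccccc2s1`, with a sulfamoyl group there, gives in this assay the limit > 50000 nM. Because all three values rest at the limit of > 50000 nM in this assay, at which 3 of the 3 values shown sit, the steps among them cannot be read: a step that the two limits leave unreadable from compound 1 to compound 2, a step that the two limits leave unreadable from compound 1 to compound 3 and a step that the two limits leave unreadable from compound 2 to compound 3 remain of unknown size and direction.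

Compound 4 `Cc1cnc(Nc2ccc(N3CCCCC3)cc2)nc1Nc1nc2ccccc2s1` differs from compound 3 by piperidin-1-yl in place of fluoro on an aromatic carbon. Among the compounds with values here, none of the measured steps can say what swapping one group for another on that ring does here, since every measured compound stops at the limit. What the three share is that isopropyl, sulfamoyl and fluoro alike leave the inhibitory concentration beyond the limit, so the fourth group is expected most likely to do the same. The resulting step is expected to be an at least 1.2-fold lower number from compound 3 to compound 4 (0.09 log units; that floor lies within the scatter), which is little more than a guess. For compound 4 the estimate in this assay is 40000 nM, with a range from 8000 nM to 200000 nM.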

Compound 4, half-maximal inhibitory concentration: > 50000 nM
Compound 4 was reported as a limit; the forecaster's own chance of this, stated with the estimate: 70%; middle value at least 1.2-fold (0.09 log units) away from the limit.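

Compound 4 also gives only a limit, so the steps to it from compound 1, compound 2 and compound 3 in this assay cannot be read, as all four compounds rest at the same limit: the limit of > 50000 nM in this assay, at which 4 of the 4 values shown sit. The compounds shown leave open whether any group at that place on the outer ring gives a readable inhibitory concentration.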